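The source may hold more compounds than are shown below. What is called first, only, known or untested is meant among the compounds shown, and "the series" means these compounds.

Compound 1 `c1cnc2c(c1)CCC[C@@H]2N(CC1CC1)C[C@H]1Cc2c(cccc2N2CCNCC2)CN1`: 88.3%
Compound 2 `CN1CCN(c2cccc3c2C[C@H](CN(C)[C@H]2CCCc4cccnc42)N(C)C3)CC1`: 41.7%

Of the compounds shown here, two have been measured in an ADME assay on microsomes from liver (Mus musculus) for metabolic stability, read by LC-MS, with a stated time of 10 min; on this read-out higher numbers stand for a more stable compound and lower numbers for a less stable compound. Compound 1 gives 88.3% in this assay, the higher of the two numbers. Compound 2 does not match compound 1 in any single place, and compound 2 gives 41.7%, a number that lies beyond the scatter below the number of compound 1. For the measured compounds named here, no step between two measured compounds that differ in one place is available, so the step to compound 3 rests on compound 1 alone.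

Compound 3 `FC1(F)CCC(CN(C[C@H]2Cc3c(cccc3N3CCNCC3)CN2)[C@H]2CCCc3cccnc32)CC1` has not yet been measured in this assay. It differs from compound 1 in one place: 4,4-difluorocyclohexyl in place of cyclopropyl on a saturated chain carbon bound to an amine nitrogen. Nothing measured speaks directly to this change. Compound 1, with 88.3%, already sits high on the read-out, so the room for a rise is small. For compound 3 a moderate fall is expected, not far beyond the scatter: a number 14.3 percentage points lower from compound 1 to compound 3 (beyond the scatter). For compound 3 the estimate in this assay is 74%, with a range from 50% to 93%.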

Compound 3, percent of the compound remaining: 76.6%
For compound 3 the middle estimate is 2.6 percentage points below the measured one; the range from low to high includes it.
By their numbers in this assay, from the lowest: compound 2; then compound 3; then compound 1.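

In this assay, for the compounds shown here, the change from cyclopropyl to 4,4-difluorocyclohexyl on a saturated chain carbon bound to an amine nitrogen gives the first direct reading at this position: a number 11.7 percentage points lower from compound 1 to compound 3 (beyond the scatter), a modest step that lies beyond the scatter. The position thus accepts a group of 8 heavy atoms in place of one of 3, and compound 3 still gives 76.6% on this read-out, so the larger ring with its two fluorine atoms lowers the number without taking it far down. Nothing available explains the fall, and this single step does not separate the size of the ring from the presence of the fluorine atoms.

The compounds shown leave open how a plain cyclohexyl, without fluorine, would read at this position in this assay, which would show how much of the step goes with the ring alone. They also leave open how a ring that carries an amine, such as piperidin-4-yl, or a longer open chain such as n-butyl, would read in its place.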